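Three Anilinopyrimidines at the Edge of Measurement

The compounds below may be only part of what the source reports. "The series", "measured", "known", "first", "only" and "open" are said of these compounds alone.

Measured so far:
compound 1, `COc1ccc(Nc2ncc(C(F)(F)F)c(N3Cc4cccc(N(C)S(C)(=O)=O)c4C3)n2)cc1C(F)(F)F`; in an assay on Sf9 cells for inhibition of tyrosine-protein kinase receptor UFO (Homo sapiens), read by luminescence and ADP-Glo (a higher number here means a weaker inhibitor, a lower number a stronger inhibitor), compound 1 gives > 20000 nM.
compound 2, `Cc1cc(C)cc(Nc2ncc(C(F)(F)F)c(N3Cc4cccc(N(C)S(C)(=O)=O)c4C3)n2)c1`; in this assay compound 2 gives > 20000 nM.

The value for compound 1 is a limit of the assay, not a number. The value for compound 2 is likewise a limit. Compound 2 therefore stands at the ceiling of what this assay can report, and it shares that position with compound 1: the limit of > 20000 nM in this assay, at which 2 of the 2 values shown sit. For the measured compounds named here, the only step between the two measured compounds, a step that the two limits leave unreadable from compound 1 to compound 2, cannot be read in size or direction, since both ends sit at the limit.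

Compound 3, `CN(c1cccc2c1CN(c1nc(Nc3ccc(Cl)c(C(F)(F)F)c3)ncc1C(F)(F)F)C2)S(C)(=O)=O`, is the next member of the series. Its change from compound 2 is 4-chloro-3-(trifluoromethyl)phenyl in place of 3,5-dimethylphenyl on a nitrogen on an aromatic ring. Going by the values given here, the single measured step that bears on this change is the one from compound 1 to compound 2, and its size is not readable, so no direction beyond the scatter can be expected for compound 3 in this assay. Compound 3 is estimated at 25000 nM, with a range from 8000 nM to 80000 nM, which means an expected step that the limit leaves unreadable from compound 2 to compound 3 and most likely another limit rather than a number.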

Compound 3, half-maximal inhibitory concentration: > 20000 nM
Compound 3: only a limit was reported; the forecaster's own chance of this, stated with the estimate: 80%; the middle value does not contradict the limit.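

In this assay compound 3 gives > 20000 nM and this is a limit, not a number. No step among compound 1, compound 2 and compound 3 can be read, since all three stand at the same ceiling: the limit of > 20000 nM in this assay, at which 3 of the 3 values shown sit.

The compounds shown leave open how far each lies beyond that limit, and whether any group on this nitrogen would give a readable value.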